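Removing the methoxy from the pendant phenyl ring

This account rests on a few compounds, and the source may have more. Where it says the series, first, only, none or still open, it means among the compounds named here.

Compound 2 `COc1ccc(-c2[nH]c3ccc(OC)cc3c2/C=C(\C#N)S(=O)(=O)c2ccccc2)cc1` is measured in a functional assay on MDA-MB-468 cells (Homo sapiens) for inhibition, read by sulforhodamine B assay, with a stated time of 48 h (on this read-out higher numbers stand for weaker inhibition of growth and lower numbers for stronger inhibition of growth), where it gives 1300 nM. Of the two plain numbers shown, that of compound 2 is one; compound 3 `CC(=O)/C(=C\c1c(-c2ccccc2)[nH]c2ccccc12)S(=O)(=O)c1ccccc1` gives 1700 nM, which sits within the usual scatter of the value of compound 2, so the two cannot be told apart. Compound 1 `COc1ccc(-c2[nH]c3ccccc3c2/C=C(\C#N)S(=O)(=O)c2ccccc2)cc1` gives < 10 nM, which is a limit of the assay rather than a number (the limit of < 10 nM in this assay, at which 1 of the 3 values shown sits).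

Compound 4 `COc1ccc2[nH]c(-c3ccccc3)c(/C=C(\C#N)S(=O)(=O)c3ccccc3)c2c1` differs from compound 2 in one place: hydrogen in place of methoxy on an aromatic carbon. The same change, cut one bond further out, reads 4-methoxyphenyl to phenyl.

Going by the values given here, no measured step covers exactly this change. Among the compounds with values here, the one measured step, an at least 130-fold higher number from compound 1 to compound 2 (2.11 log units; beyond the scatter), concerns a methoxy added on the other aromatic ring, which compound 4 keeps. Compound 3 shares the plain phenyl of compound 4 but carries an acetyl instead of a nitrile, so it only loosely hints at the outcome. A step of moderate size in either direction, or none beyond the scatter, is therefore expected: a 1.2-fold higher number from compound 2 to compound 4 (0.06 log units; within the scatter). Compound 4 is estimated to give 1500 nM, with a range from 400 nM to 6000 nM.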

Compound 4, concentration for 50% growth inhibition: 4200 nM
For compound 4 the middle estimate is 2.8-fold (0.45 log units) below the measured one; the range from low to high includes it.
By their numbers in this assay, from the lowest: compounds 2 and 3 (each within the scatter of the next); then compound 4. At a limit, below all of these: compound 1.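

In this assay, going by these compounds alone, taking the methoxy off the pendant ring gives a 3.2-fold higher number from compound 2 to compound 4 (0.51 log units; beyond the scatter), so the first measured change at this position is a real loss of growth inhibition, though a modest one, and in this setting the 4-methoxyphenyl does better than the plain phenyl. The earlier compounds shown here showed only the methoxy on the other aromatic ring, where its presence went with a higher number, so the same group goes with opposite results in the two places: on the pendant ring having it goes with a lower number, and on the other ring with a higher one. Nothing among the measurements shown gives a reason for this step, which for now stands as an observation on a single pair of compounds.

As far as these compounds go, whether the change would read the same on compound 1, which lacks the methoxy on the other ring, stays open, and any step there could differ in size from this one. Also open, from the compounds shown here alone, is how a hydroxyl, an amine or an ethoxy chain in this place on the pendant ring would compare with the methoxy and with hydrogen.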